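Phenyl for Amino on the Carbonyl: Expecting Little Movement

The compounds below may be only part of what the source reports. "The series", "measured", "known", "first", "only" and "open" are said of these compounds alone.

Within the data shown here, compound 2 `N#C/C(=C\N1CCN(C(=O)c2ccco2)C1=S)C(N)=O` gives 18000 nM in a functional assay on 786-0 cells (Homo sapiens) for inhibition, read by sulforhodamine B assay, with a stated time of 48 h; on this read-out higher numbers stand for weaker inhibition of growth and lower numbers for stronger inhibition of growth; it is one of only two numbers so far, and compound 1 `N#C/C(=C\N1CCN(C(=O)c2ccco2)C1=S)C(=O)Nc1ccc(Cl)cc1` gives 17400 nM, the two lying within the scatter of each other. Compound 3 `N#C/C(=C\N1CCN(C(=O)c2ccco2)C1=S)C(=O)c1ccccc1` is not yet measured; it differs from compound 2 by phenyl in place of amino on a carbonyl carbon. Among the measured compounds shown here, the only known step, a 1.0-fold higher number from compound 1 to compound 2 (0.01 log units; within the scatter), changed the same end of the shared core without moving the number beyond the scatter. Compound 3 is therefore expected to show no change at the digits printed from compound 2 to compound 3 (within the scatter), nothing beyond the scatter. The estimate for compound 3 is 18000 nM, within a range from 6000 nM to 50000 nM.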

Compound 3, concentration for 50% growth inhibition: 16100 nM
The estimate for compound 3 lay 1.1-fold (0.05 log units) above the measured number, and the stated range covers the measured number.
By their numbers in this assay, from the lowest: compounds 3, 1 and 2 (each within the scatter of the next).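

In this assay the change of amino to phenyl on this carbonyl carbon gives a 1.1-fold lower number from compound 2 to compound 3 (0.05 log units; within the scatter) and the change of (4-chlorophenyl)amino to phenyl gives a 1.1-fold lower number from compound 1 to compound 3 (0.03 log units; within the scatter). Compound 3 has no amide-type nitrogen at this position, so removing that nitrogen, like changing its substituent earlier, does not move the number beyond the scatter. No supporting measurement bears on this result. From the compounds shown here alone, whether a hydroxyl group or a butyl chain on this carbonyl carbon would move the number beyond the scatter remains open.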